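Compound 3 to compound 4: an expected step

The source may report more compounds than this note shows. Statements on the series, on what has been measured and on what is new or still open speak of the compounds shown alone.

Values in a physicochemical assay for permeability, using PAMPA; on this read-out higher numbers stand for higher permeability and lower numbers for lower permeability:
- compound 1 `COCCOc1cc2oc(=O)n(CCC(=O)O)c2cc1Cl`: < 3 nm/s (a limit)
- compound 2 `O=C(O)CCn1c(=O)oc2cc(Cl)c(Cl)cc21`: 24 nm/s
- compound 3 `CC(C)Cc1cc2oc(=O)n(CCC(=O)O)c2cc1Cl`: < 10 nm/s (a limit)

Compound 3 stands at < 10 nm/s in this assay, which is a limit and not a number. Compound 4 `O=C(O)CCn1c(=O)oc2cc(OCc3ccccn3)c(Cl)cc21` carries (pyridin-2-yl)methoxy in place of isobutyl on an aromatic carbon, ortho to a chloro group: (pyridin-2-yl)methoxy in place of isobutyl on an aromatic carbon.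

All three measured steps exchange the group on an aromatic carbon. Chloro in place of 2-methoxyethoxy gives an at least 8.0-fold higher number from compound 1 to compound 2 (0.90 log units; beyond the scatter), and isobutyl in place of chloro gives an at least 2.4-fold lower number from compound 2 to compound 3 (0.38 log units; beyond the scatter). Isobutyl in place of 2-methoxyethoxy gives a step that the two limits leave unreadable from compound 1 to compound 3. Among these compounds, only compound 2, with chloro, reads as a number. Compound 1, whose group also joins through oxygen, stands at < 3 nm/s, again a limit.

Compound 4 is therefore expected to stay at the low end of this assay, with no rise towards compound 2. The step expected is a step that the limit leaves unreadable from compound 3 to compound 4. For compound 4 the estimate is 4 nm/s, with an expected range from 1 nm/s to 12 nm/s.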

Compound 4, apparent permeability: 11 nm/s
Compound 4: the middle estimate sits 2.8-fold (0.44 log units) below what was measured; low and high end bracket the measured number.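

In this assay, compound 4 gives 11 nm/s, which shows that a group joined through oxygen at this position, ortho to a chloro group, can give a readable number, with an at least 3.6-fold higher number from compound 1 to compound 4 (0.56 log units; beyond the scatter). Chloro still stands apart from the larger ring-bearing group, with a 2.2-fold lower number from compound 2 to compound 4 (0.34 log units; beyond the scatter). The comparison with isobutyl gives an at least 1.1-fold higher number from compound 3 to compound 4 (0.04 log units; that floor lies within the scatter), and no order between these two groups can be drawn because this step rests on a limit: the limit of < 10 nm/s in this assay, at which 1 of the 4 values shown sits.

Benzyloxy at this position would test whether the nitrogen of the (pyridin-2-yl)methoxy ring plays any part in this read-out, and methoxy would test the oxygen link without a ring. Going by these compounds, whether any group at this position can match or exceed chloro remains open.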